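A few compounds are considered here, and "the series" means these few. Any claim that something is new, unique, unknown or untested is made for them only; others in the source may bear on it.

Compound 1 `O=C(C1CCC(F)(F)CC1)N1CC(c2nc(-c3cccc(Cl)c3)no2)C1` carries a 4,4-difluorocyclohexyl on a carbonyl carbon of the shared core. In an assay on HEK293 cells for negative allosteric modulation of metabotropic glutamate receptor 5 (Homo sapiens), read by FLIPR (on this read-out higher numbers stand for weaker inhibition and lower numbers for stronger inhibition), compound 1 gives > 10000 nM, which is a limit of the assay rather than a measured number. Compound 2 `O=C(C1CCCCC1)N1CC(c2nc(-c3cccc(F)c3)no2)C1` is a close relative, and in this assay compound 2 likewise gives > 10000 nM, again only a limit. Going by the values given here, compound 3 `Cc1ccc(S(=O)(=O)N2CC(c3nc(-c4cccc(Cl)c4)no3)C2)cc1` is the one member of the set with a numerical result: in this assay compound 3 gives 920 nM. Among the compounds with values here, compound 1 therefore stands at the limit of > 10000 nM in this assay, at which 2 of the 3 values shown sit, and no step between two measured compounds is available to guide expectations.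

Compound 4 `COC1CCCN(C(=O)N2CC(c3nc(-c4cccc(Cl)c4)no3)C2)C1` differs from compound 1 by 3-methoxypiperidin-1-yl in place of 4,4-difluorocyclohexyl on a carbonyl carbon. Within the data shown here, no measured step covers this kind of change, so the expectation rests only on where compound 1 sits. The step of an at least 1.1-fold lower number from compound 1 to compound 4 (0.04 log units; that floor lies within the scatter) is expected to be small, with compound 4 most likely staying close to the limit. Compound 4 is accordingly estimated at 9000 nM, within a range from 2000 nM to 30000 nM.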

Compound 4, half-maximal inhibitory concentration: 1830 nM
Estimate against measurement, compound 4: 4.9-fold (0.69 log units) above; the measured number lies below the stated range.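

Replacing 4,4-difluorocyclohexyl with 3-methoxypiperidin-1-yl on this carbonyl carbon gives an at least 5.4-fold lower number from compound 1 to compound 4 (0.73 log units; beyond the scatter). Going by these compounds alone, this is the first one-place comparison in the set, and it shows that this position can decide whether a compound gives a measurable number in this assay, even though the two groups have the same count of heavy atoms and each holds a six-membered non-aromatic ring. The true size of the step remains unknown, as it starts from a limit rather than a measured number: the limit of > 10000 nM in this assay, at which 2 of the 4 values shown sit.

The entering group differs from the leaving one by both a ring nitrogen and a methoxy, and this single comparison cannot separate the two. A plain piperidin-1-yl, without the methoxy, or a morpholin-4-yl at the same place would be needed to show which of them goes with the lower number.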